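The compounds below may be only part of what the source reports. "The series", "measured", "known", "first", "only" and "open" are said of these compounds alone.

Values from an assay on HEK293 cells for displacement of a labelled ligand from 5-hydroxytryptamine receptor 7 (Rattus norvegicus), with a stated time of 60 min; on this read-out lower numbers stand for stronger inhibition and higher numbers for weaker inhibition:

compound 1, `c1ccc(Cn2cc(-c3ccccc3)c3c2CCNC3)cc1`: 220 nM
compound 2, `Clc1ccc(-c2cn(Cc3ccccc3)c3c2CNCC3)cc1Cl`: 4470 nM
compound 3, `Clc1ccc(-c2cn(Cc3ccccc3)c3c2CNCC3)c(Cl)c1`: 2070 nM

Compound 1 holds the lowest number of the three. The two dichloro analogues sit well behind it: a 20-fold higher number from compound 1 to compound 2 (1.31 log units; beyond the scatter) and a 9.4-fold higher number from compound 1 to compound 3 (0.97 log units; beyond the scatter), with the two chlorination patterns themselves separated, a 2.2-fold lower number from compound 2 to compound 3 (0.33 log units; beyond the scatter). Within this small set, putting chlorine on the aryl ring carried by the core has only raised the number.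

Compound 4, `Clc1ccccc1Cn1cc(-c2ccccc2)c2c1CCNC2`, is the next compound to be measured. It differs from compound 1 by chloro in place of hydrogen on an aromatic carbon. Within the data shown here, this chlorine sits on a different ring from the one altered in the steps from compound 1 to compound 2 and to compound 3, so none of the measured steps tests the same position; they only show that chlorine on the other ring cost binding, and by one chlorine rather than two the present change is smaller than either of those. The expectation is therefore a weakening at most modest in size, possibly none beyond the scatter, a 1.6-fold higher number from compound 1 to compound 4 (0.20 log units; within the scatter). Compound 4 is expected to give 350 nM, within a range of 120 nM to 1000 nM.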

Compound 4, inhibition constant: 22900 nM
Compound 4: the middle estimate sits 65-fold (1.82 log units) below what was measured, and the stated range ends below it.
By their numbers in this assay, from the lowest: compound 1; then compound 3; then compound 2; then compound 4.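

In this assay, among these compounds, the change from phenyl to 2-chlorophenyl is the first reading on this ring, and one chlorine, ortho to a large group, is enough to give a 100-fold higher number from compound 1 to compound 4 (2.02 log units; beyond the scatter). This step is larger than either step from compound 1 to a dichloro analogue, so in these four compounds the loss of binding is not tied to the number of chlorines, and the ring altered here is the more sensitive of the two aryl rings to chlorine. The data offer no measurement that explains why a single heavy atom in place of hydrogen has so large an effect at this place.

The compounds shown leave open whether this loss belongs to chloro itself or would also appear with fluoro, methyl or methoxy at the same place. They also leave open whether chloro elsewhere on this ring would be tolerated, and whether a single chloro on the other aryl ring would cost less than the two chlorines of compound 2 and compound 3.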